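Cytotoxicity limits along an amide-substituent change

The compounds below may be only part of what the source reports. "The series", "measured", "known", "first", "only" and "open" are said of these compounds alone.

Measured compounds:
Compound 1 `C#CCNC(=O)/C=C/c1cnc(Nc2ccc(C#N)cc2)nc1Oc1c(C)cc(C#N)cc1C` gives > 222 nM in an ADME assay on TZM cells (Homo sapiens) for cytotoxicity, with a stated time of 1 days; on this read-out higher numbers stand for lower toxicity in this test and lower numbers for higher toxicity in this test.
Compound 2 `Cc1cc(C#N)cc(C)c1Oc1nc(Nc2ccc(C#N)cc2)ncc1/C=C/C(=O)NC1CCN(S(C)(=O)=O)C1` gives > 179 nM in this assay.

Both values are limits of the assay rather than numbers. Among the measured compounds shown here, compound 2 therefore stands only at a limit in this assay, and compound 1 stands at a limit as well, so the one measured step, a step that the two limits leave unreadable from compound 1 to compound 2, cannot be read, because both values sit at limits the limit of > 179 nM in this assay, at which 1 of the 2 values shown sits, and (the limit of > 222 nM in this assay, at which 1 of the 2 values shown sits).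

Compound 3 `Cc1cc(C#N)cc(C)c1Oc1nc(Nc2ccc(C#N)cc2)ncc1/C=C/C(=O)N1CCN(S(C)(=O)=O)CC1` differs from compound 2 by 4-(methylsulfonyl)piperazin-1-yl in place of (1-(methylsulfonyl)pyrrolidin-3-yl)amino on a carbonyl carbon, a change in which the same atoms are joined differently. For the measured compounds named here, the only measured step that bears on this change is the one from compound 1 to compound 2, and its size is not readable, so no direction can be taken from it. Compound 3 is expected to be reported as a limit in this assay, with the step that the limit leaves unreadable from compound 2 to compound 3 expected to be unreadable or within scatter. The estimate for compound 3 in this assay is 250 nM, with a range from 150 nM to 2000 nM.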

Compound 3, half-maximal cytotoxic concentration: > 179 nM
Compound 3 was reported as a limit; the forecaster's own chance of this, stated with the estimate: 85%; the middle value lies beyond the limit too.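

In this assay compound 3 gives > 179 nM, which is a limit and not a number. The steps linking compound 1, compound 2 and compound 3 cannot be read, because their values are limits: the limit of > 179 nM in this assay, at which 2 of the 3 values shown sit. The compounds shown leave open the actual half-maximal cytotoxic concentration of all three, and whether 4-(methylsulfonyl)piperazin-1-yl in place of (1-(methylsulfonyl)pyrrolidin-3-yl)amino changes it at all.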